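A few compounds are considered here, and "the series" means these few. Any claim that something is new, unique, unknown or untested is made for them only; others in the source may bear on it.

Two pairs of compounds share one structural change. Compound 2 `CCN(c1ccc(C#N)c(Cl)c1)c1cc(-c2cncnc2)ccc1C` and compound 1 `CCN(c1ccc(C#N)c(Cl)c1)c1cc(-c2ccncc2)ccc1C` were both tested in a functional assay on VCaP cells (Homo sapiens) for antiproliferative activity, read by CCK-8 assay, with a stated time of 6 days; a lower number here means a stronger inhibitor, a higher number a weaker inhibitor. In this assay compound 2 gives 3920 nM, and compound 1 gives 2900 nM. The change between them is pyridin-4-yl in place of pyrimidin-5-yl on an aromatic carbon and the step is a 1.4-fold lower number from compound 2 to compound 1 (0.13 log units; within the scatter), so the two numbers cannot be told apart with confidence.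

Compound 3 `N#Cc1ccc(N2CCc3cc(-c4cncnc4)ccc3C2)cc1C(F)(F)F` carries a different core; the difference between the core of compound 3 and the core of compound 2 is not broken down here. In this assay compound 3 gives "not determined" (no result reported), so no result for it is reported. Compound 4 `N#Cc1ccc(N2CCc3cc(-c4ccncc4)ccc3C2)cc1C(F)(F)F` is the partner of compound 3, and the change is pyridin-4-yl in place of pyrimidin-5-yl on an aromatic carbon. Going by the values given here, this is the same kind of change as the one from compound 2 to compound 1, though the surroundings differ: in compound 2 the aromatic carbon is meta to a large group and para to a methyl group (1 heavy atom), while in compound 3 it is part of a fused or bridged system of two rings, meta to a fused ring and para to a fused ring.

Among the compounds with values here, compound 3 has no number, and no step to compound 4 can be formed from it. What remains is that the same kind of change left compound 2 and compound 1 within the usual scatter, as a 1.4-fold lower number from compound 2 to compound 1 (0.13 log units; within the scatter) shows, so a small shift is expected for compound 4 relative to whatever compound 3 would give. Going by these compounds, how the new core itself behaves is unknown, so the estimate is wide. In this assay compound 4 is expected to give about 3000 nM, with an expected range from 600 nM to 15000 nM.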

Compound 4, half-maximal inhibitory concentration: 3500 nM
The estimate for compound 4 lay 1.2-fold (0.07 log units) below the measured number; measured number inside the range.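

Going by these compounds alone, compound 3 has no number in this assay, so no step from compound 3 to compound 4 can be read, and the change from pyrimidin-5-yl to pyridin-4-yl on this core has no size here. Nothing available explains the result for compound 4. The compounds shown leave open whether this change behaves on this core as it does on the core of compound 2.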